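The source may hold more compounds than are shown below. What is called first, only, known or untested is meant among the compounds shown, and "the series" means these compounds.

Working notes on the series. Going by the values given here, in a functional assay on MDA-MB-231 cells (Homo sapiens) for cytotoxicity, read by MTT assay, with a stated time of 48 h (on this read-out lower numbers stand for stronger inhibition and higher numbers for weaker inhibition), compound 3 `O=c1ccoc2cc(OCc3cn(Cc4ccc([N+](=O)[O-])cc4)nn3)ccc12` gives 71300 nM as the only true number so far. Compound 1 `Cc1ccccc1Cn1cc(COc2ccc3c(=O)ccoc3c2)nn1` reads > 100000 nM and this is a limit of the assay. Compound 2 `O=c1ccoc2cc(OCc3cn(Cc4cccc([N+](=O)[O-])c4)nn3)ccc12` reads > 100000 nM and this too is a limit. The commonest reading is therefore the limit of > 100000 nM in this assay, at which 2 of the 3 values shown sit, and it restricts what the steps can show.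

Compound 4 `O=c1ccoc2cc(OCc3cn(Cc4ccccc4Br)nn3)ccc12` carries 2-bromophenyl in place of 4-nitrophenyl on a saturated chain carbon bound to an aromatic nitrogen, counted as 2-bromophenyl in place of 4-nitrophenyl on a saturated chain carbon bound to an aromatic nitrogen in full.

The measured steps are an at least 1.4-fold lower number from compound 1 to compound 3 (0.14 log units; that floor lies within the scatter) and an at least 1.4-fold lower number from compound 2 to compound 3 (0.14 log units; that floor lies within the scatter) while the third is a step that the two limits leave unreadable from compound 1 to compound 2 and adds nothing. The nearest guide is compound 1, which bears 2-methylphenyl at that place, and an at least 1.4-fold lower number from compound 1 to compound 3 (0.14 log units; that floor lies within the scatter) taken in reverse suggests a higher number, if any change appears.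

The estimated change is a 1.3-fold higher number from compound 3 to compound 4 (0.12 log units; within the scatter) and it is expected to stay small, with no clear move beyond the scatter in this assay here. For compound 4 the expected value is 95000 nM within an estimated range of 45000 nM to 200000 nM in this read-out, and a report as a bare limit is quite possible.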

Compound 4, half-maximal inhibitory concentration: > 100000 nM
Compound 4: only a limit was reported (the forecaster's own chance of this, stated with the estimate: 55%); at least 1.0-fold (0.02 log units) between middle value and limit.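

In this assay, 2-bromophenyl in place of 4-nitrophenyl on a saturated chain carbon bound to an aromatic nitrogen gives an at least 1.4-fold higher number from compound 3 to compound 4 (0.14 log units; that floor lies within the scatter), so this change shows no step beyond the scatter, although the true size may be larger than that floor. Compound 4 is reported only as a limit, and the steps to it from compound 1 and from compound 2 join two limits and cannot be read. Going by these compounds alone, compound 3 therefore remains the only compound with a true number, and the limit is now more common still: the limit of > 100000 nM in this assay, at which 3 of the 4 values shown sit.

Going by these compounds, whether any group at this place can move the number clearly beyond the scatter from compound 3 stays open. Also open, on these data alone, is how an amine or a carboxylic acid on the phenyl ring, or a longer chain in place of the single chain carbon, would read here.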